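The source may hold more compounds than are shown below. What is called first, only, known or untested is meant among the compounds shown, and "the series" means these compounds.

Measured in a functional assay on MDA-MB-231 cells (Homo sapiens) for antiproliferative activity, read by MTT assay, with a stated time of 48 h; a higher number here means a weaker inhibitor, a lower number a stronger inhibitor:
- compound 1 `C#Cc1cccc(Nc2ncnc3cc(NC(=O)/C=C/c4ccccc4)sc23)c1`: 2340 nM
- compound 2 `COc1ccc(/C=C/C(=O)Nc2cc3c(Nc4ccc(Cl)c(Cl)c4)ncnc3s2)cc1`: 16600 nM
- compound 3 `O=C(/C=C/c1ccccc1)Nc1cc2c(Nc3cc(Cl)cc(Cl)c3)ncnc2s1`: 11500 nM

Compound 1 has the lowest number of the three, and both gaps to it lie beyond the scatter. Compound 4 `O=C(/C=C/c1ccccc1)Nc1cc2ncnc(Nc3ccc(Cl)c(Cl)c3)c2s1` keeps the core of compound 1 and has 3,4-dichlorophenyl in place of 3-ethynylphenyl on a nitrogen on an aromatic ring. Going by the values given here, no measured pair isolates this change. The chlorine-bearing analogues, compound 2 at 16600 nM and compound 3 at 11500 nM, sit higher, but their core differs from that of compound 1, so they are only a loose guide. A moderate rise in the number is expected, a 2.4-fold higher number from compound 1 to compound 4 (0.37 log units; beyond the scatter). For compound 4 the estimated value is 5500 nM, with an expected range of 1800 nM to 16000 nM.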

Compound 4, half-maximal inhibitory concentration: 2410 nM
Compound 4: middle estimate off by 2.3-fold (0.36 log units), on the high side; low and high end bracket the measured number.
By their numbers in this assay, from the lowest: compounds 1 and 4 (each within the scatter of the next); then compounds 3 and 2 (each within the scatter of the next).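

In this assay, 3,4-dichlorophenyl in place of 3-ethynylphenyl on the nitrogen gives a 1.0-fold higher number from compound 1 to compound 4 (0.01 log units; within the scatter), a step within the scatter. On this core, therefore, the position takes either group with no readable change, and the ethynyl group is not required to hold the number at this level. No measurement available gives a reason for this result.

Going by these compounds, whether a more different group on this nitrogen, such as a phenyl ring carrying a carboxylic acid or an amine, would hold the number remains open. A simple alkyl chain in place of the phenyl ring is equally untested here.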